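A trifluoromethyl swap at the edge of measurement

The source may report more compounds than this note shows. Statements on the series, on what has been measured and on what is new or still open speak of the compounds shown alone.

Among the compounds with values here, in an ADME assay on HEK293 cells (Homo sapiens) for cytotoxicity, read by resazurin assay, with a stated time of 48 h (on this read-out higher numbers stand for lower toxicity in this test and lower numbers for higher toxicity in this test), compound 1 (`Cc1ccc(S(=O)(=O)Nc2ccc(-c3nc4ccccc4o3)cc2)cc1`) gives 88000 nM as the only actual number in this small set. Compound 2 (`O=S(=O)(Nc1ccc(-c2nc3ccccc3o2)cc1)c1cccc(Cl)c1`) returns only a limit (> 100000 nM). Compound 3 (`O=S(=O)(Nc1ccc(-c2nc3ccccc3o2)cc1)c1ccccc1F`) also returns only a limit (> 100000 nM). Compound 4 (`O=S(=O)(Nc1ccc(-c2nc3ccccc3o2)cc1)c1ccc(C(F)(F)F)cc1`) differs from compound 1 by a single change (trifluoromethyl in place of methyl on an aromatic carbon). Within the data shown here, no measured step makes this exact replacement, but two replace the same 4-methylphenyl group on the sulfonyl sulfur (an at least 1.1-fold higher number from compound 1 to compound 2 (0.05 log units; that floor lies within the scatter)) and (an at least 1.1-fold higher number from compound 1 to compound 3 (0.05 log units; that floor lies within the scatter)). Both floors lie within the scatter, so in this assay no step beyond it is expected. The expected step (a 1.1-fold higher number from compound 1 to compound 4 (0.06 log units; within the scatter)) therefore stays small. Compound 4 is estimated at 100000 nM (expected range 55000 nM to 180000 nM).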

Compound 4, half-maximal cytotoxic concentration: 94000 nM
Compound 4: the middle estimate sits 1.1-fold (0.03 log units) above what was measured, and the stated range covers the measured number.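

In this assay, this position now gives a step that can be read in full, where the earlier replacements of the 4-methylphenyl group gave only floors: a 1.1-fold higher number from compound 1 to compound 4 (0.03 log units; within the scatter). That step lies within the scatter, so trifluoromethyl in place of methyl on this aromatic carbon, para to a large group, shows no change that can be told from repeat measurement.

From the compounds shown here alone, whether an amine or a carboxylic acid on this carbon would give a step beyond the scatter stays open. Any such rise would also be hard to read, because the values crowd the top of the assay's range: the limit of > 100000 nM in this assay, at which 2 of the 4 values shown sit.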